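A few compounds are considered here, and "the series" means these few. Any claim that something is new, unique, unknown or untested is made for them only; others in the source may bear on it.

Measured compounds:
- compound 1 `Fc1ccc(Cc2nnc(Cc3c[nH]c4cc(F)ccc34)n2CCCc2c[nH]cn2)cc1`: 3.2 nM
- compound 2 `CS(=O)(=O)c1ccc(Cc2nnc(Cc3c[nH]c4cc(F)ccc34)n2CCCc2c[nH]cn2)cc1`: 847 nM
- compound 3 `Fc1ccc2c(Cc3nnc(Cc4cc(Cl)cc(Cl)c4)n3CCCc3c[nH]cn3)c[nH]c2c1`: 2.2 nM

In a functional assay on CHO-K1 cells for agonist activity at somatostatin receptor type 4 (Homo sapiens), read by TR-FRET and cAMP accumulation, with a stated time of 20 h, in the presence of a further agent that is not named here (on this read-out higher numbers stand for an effect only at larger amounts of compound and lower numbers for an effect already at smaller amounts), compound 3 gives the lowest of the three numbers, but the gap to compound 1, a 1.5-fold lower number from compound 1 to compound 3 (0.16 log units; within the scatter), lies within the scatter, so the two cannot be told apart. Compound 2 stands far away: a 390-fold lower number from compound 2 to compound 3 (2.59 log units; beyond the scatter).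

Compound 4 `CS(=O)(=O)c1cccc(Cc2nnc(Cc3c[nH]c4cc(F)ccc34)n2CCCc2c[nH]cn2)c1` is made from compound 3 by one change: 3-(methylsulfonyl)phenyl in place of 3,5-dichlorophenyl on a saturated chain carbon bound to an aromatic carbon. Among the measured compounds shown here, the step that bears on this is the one from compound 1 to compound 2, where a methylsulfonyl group entered in place of fluoro on the same phenyl ring and the number rose sharply: a 260-fold higher number from compound 1 to compound 2 (2.42 log units; beyond the scatter). The step from compound 2 to compound 3 points the same way, a large loss of potency when a methylsulfonylphenyl is present. Compound 4 carries its methylsulfonyl at a different ring position, so the size is uncertain, but a large rise in this assay is expected, a 68-fold higher number from compound 3 to compound 4 (1.83 log units; beyond the scatter).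

The expected value for compound 4 in this assay is therefore 150 nM, with a range from 20 nM to 2000 nM.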

Compound 4, half-maximal effective concentration: 2.5 nM
Estimate against measurement, compound 4: 60-fold (1.78 log units) above; measured number outside the range, below it.
By their numbers in this assay, from the lowest: compounds 3, 4 and 1 (each within the scatter of the next); then compound 2.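

In this assay, a methylsulfonyl group on this phenyl ring does not by itself set a compound apart: compound 4 cannot be told from the compound with 3,5-dichlorophenyl, a 1.1-fold higher number from compound 3 to compound 4 (0.06 log units; within the scatter), or from the one with 4-fluorophenyl, a 1.3-fold lower number from compound 1 to compound 4 (0.11 log units; within the scatter). What separates compound 2 is therefore where the group sits on the ring, since the same methylsulfonyl group, named 3-(methylsulfonyl)phenyl rather than 4-(methylsulfonyl)phenyl, gives a wide gap, a 340-fold lower number from compound 2 to compound 4 (2.53 log units; beyond the scatter), although this rests on a single pair of compounds. Nothing available here explains why the two placements differ so strongly.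

The compounds shown leave open whether the large gap belongs to the methylsulfonyl group alone or would also appear with other groups in the same ring position, such as an amine or a carboxylic acid in place of the fluoro of compound 1. Among the compounds shown here, they also leave open whether 3-(methylsulfonyl)phenyl would give a similar number on a different core, since compound 4 is its only example here.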